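Thiophene replaces dichlorophenyl on a pyrazoline thiourea core

This account rests on a few compounds, and the source may have more. Where it says the series, first, only, none or still open, it means among the compounds named here.

Three analogues sharing one core have been tested in a functional assay on HT-29 cells (Homo sapiens) for antiproliferative activity, read by MTT assay, with a stated time of 48 h; a higher number here means a weaker inhibitor of growth, a lower number a stronger inhibitor of growth. Compound 1 `FC(F)(F)c1ccc(C2=NN(C(=S)Nc3ccccc3)C(c3ccc4c(c3)OCCO4)C2)cc1` gives 97500 nM. Compound 2 `O=[N+]([O-])c1ccc(C2=NN(C(=S)Nc3ccccc3)C(c3ccc4c(c3)OCCO4)C2)cc1` gives 153000 nM. Compound 3 `S=C(Nc1ccccc1)N1N=C(c2ccc(Cl)c(Cl)c2)CC1c1ccc2c(c1)OCCO2` gives 95300 nM. The three numbers lie close together: a 1.0-fold lower number from compound 1 to compound 3 (0.01 log units; within the scatter) and a 1.6-fold lower number from compound 2 to compound 3 (0.21 log units; within the scatter), so compound 3 stands among its neighbours rather than apart from them, and none of the three can be called the stronger or weaker inhibitor.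

Compound 4 `S=C(Nc1ccccc1)N1N=C(c2cccs2)CC1c1ccc2c(c1)OCCO2` is not yet measured. It differs from compound 3 by thiophen-2-yl in place of 3,4-dichlorophenyl on a carbon with a double bond to nitrogen. The two steps that bear on this change are those at the same position, from compound 1 and from compound 2 to compound 3, which swapped one aryl group for another on the carbon with a double bond to nitrogen, and both stayed within the scatter. On that basis no step beyond the scatter is expected in this assay, in either direction. The expected step is a 1.0-fold higher number from compound 3 to compound 4 (0.02 log units; within the scatter), and compound 4 is therefore estimated at 100000 nM, with a range from 35000 nM to 300000 nM.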

Compound 4, concentration for 50% growth inhibition: 188000 nM
Compound 4: the middle estimate sits 1.9-fold (0.27 log units) below what was measured, within the range that was stated.
By their numbers in this assay, from the lowest: compounds 3, 1, 2 and 4 (each within the scatter of the next).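

Until now this position had held only substituted phenyl groups, and thiophen-2-yl brings a five-membered aromatic ring with 1 hetero atom to it, with all three steps in this assay staying within the scatter (a 2.0-fold higher number from compound 3 to compound 4 (0.30 log units; within the scatter)) (a 1.2-fold higher number from compound 2 to compound 4 (0.09 log units; within the scatter)) (a 1.9-fold higher number from compound 1 to compound 4 (0.29 log units; within the scatter)). Among these four compounds, then, neither the change from a six-membered aromatic ring of carbon only to thiophen-2-yl nor the loss of the two chlorine atoms sets any compound apart in this assay. No further data bear on this result.

Going by these compounds, all four compounds keep an aromatic ring at this position, so the effect of an amine, a carboxylic acid or a longer alkyl chain there remains open. The 2,3-dihydro-1,4-benzodioxin-6-yl group is also the same throughout, so these compounds say nothing about replacing it.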